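The source may hold more compounds than are shown below. What is called first, only, known or untested is meant among the compounds shown, and "the series" means these compounds.

Measured compounds:
Compound 1 `CCCCC/C(=C\B1OC(C)(C)C(C)(C)O1)C(O)(c1ccccc1)C1CC1` — "not active" (no number reported)
Compound 2 `CCC/C(=C\B1OC(C)(C)C(C)(C)O1)C(O)(c1ccccc1)C1CC1` — 83900 nM

Of the compounds shown here, two sharing the same core have been tested in a functional assay on HT-29 cells (Homo sapiens) for cytotoxicity, read by MTT assay, with a stated time of 72 h; a higher number here means a weaker inhibitor, a lower number a stronger inhibitor. Compound 1 `CCCCC/C(=C\B1OC(C)(C)C(C)(C)O1)C(O)(c1ccccc1)C1CC1` is recorded in this assay as "not active" (no number reported), an entry that carries no number. For the measured compounds named here, compound 2 `CCC/C(=C\B1OC(C)(C)C(C)(C)O1)C(O)(c1ccccc1)C1CC1` is the only compound with a numerical result; in this assay compound 2 gives 83900 nM, a weak value that stands alone, so no step between measured compounds can be drawn.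

Compound 3 `CCCCCCCC/C(=C\B1OC(C)(C)C(C)(C)O1)C(O)(c1ccccc1)C1CC1` has not yet been measured. It differs from compound 2 by pentyl in place of hydrogen on a saturated chain carbon, three bonds along the chain from a double-bonded chain carbon, which lengthens the saturated chain well beyond that of compound 2 and also beyond that of compound 1. Going by the values given here, the data give no measured step for chain lengthening, but the chain of compound 2 is shorter than that of compound 1, and compound 1 returned "not active" (no number reported), while compound 2 gives 83900 nM. On that basis the step of a 2.4-fold higher number from compound 2 to compound 3 (0.38 log units; beyond the scatter) is expected to go toward weaker inhibition, by more than the scatter, and quite possibly to an entry without a number. Compound 3 is therefore estimated at 200000 nM, with a range from 60000 nM to 600000 nM.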

Compound 3, half-maximal inhibitory concentration: 18300 nM
Compound 3: the middle estimate sits 11-fold (1.04 log units) above what was measured; the whole stated range lies above it.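

In this assay, the change from propyl to octyl gives a 4.6-fold lower number from compound 2 to compound 3 (0.66 log units; beyond the scatter), so this saturated chain position tolerates a substantial extension, and the longer chain here goes with stronger inhibition rather than the loss of measurable activity. The trend is not simple, however: with a chain longer than that of compound 2 and shorter than that of compound 3, compound 1 goes against any steady gain with length, as it is recorded as "not active" (no number reported). No supporting evidence bears on this result, so the compounds shown give no explanation for the step or for the uneven order along the series.

For the compounds shown here, the three compounds leave open whether a longer chain than octyl would continue the gain seen with compound 3 or lose it, and with only one numerical step, the shape of the relation between chain length and activity remains undefined. They also leave open whether a chain carrying an amine or a carboxylic acid at this position would keep the activity of compound 3 in this assay.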